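The source may report more compounds than this note shows. Statements on the series, on what has been measured and on what is new or still open speak of the compounds shown alone.

Of the compounds shown here, two sharing one core have been tested so far in a functional assay (muscle tissue) with Cavia porcellus as the target; a higher number here means that more compound is needed for the effect, a lower number that less compound is needed. Compound 1 (`COC(=O)C1=C(C)N=C(C)/C(=C(\O)OC)C1c1ccc(F)cc1`) gives 129 nM and compound 2 (`COC(=O)C1=C(C)N=C(C)/C(=C(\O)OC)C1c1cccc(N(C)C)c1`) gives 891 nM as its half-maximal effective concentration. Compound 2 therefore holds the higher of the two numbers, and its gap to compound 1 lies beyond the usual scatter of repeated measurements.

Compound 3 (`COC(=O)C1=C(C)N=C(C)/C(=C(\O)OC)C1c1cccc(N)c1`) keeps the shared core and differs from compound 2 in one group: it has amino in place of dimethylamino on an aromatic carbon, meta to a large group (amino in place of dimethylamino on an aromatic carbon). Going by the values given here, no measured pair shows this change on its own, so the data offer only a rough guide. The gap between compound 2 at 891 nM and compound 1 at 129 nM shows how far numbers on this core can differ, and a smaller move than that seems the reasonable expectation. The estimated step in this assay is a 2.2-fold lower number from compound 2 to compound 3 (0.35 log units; beyond the scatter) as a modest move towards a lower number, only slightly beyond the scatter. For compound 3 the half-maximal effective concentration is expected to be 400 nM (estimated range 110 nM to 1400 nM).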

Compound 3, half-maximal effective concentration: 2000 nM
For compound 3 the middle estimate is 5.0-fold (0.70 log units) below the measured one; measured number above the stated range.
By their numbers in this assay, from the lowest: compound 1; then compound 2; then compound 3.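

In this assay, going by these compounds alone, the step to the primary amine is the first measured change at this aromatic carbon, meta to a large group: replacing dimethylamino with amino, which has fewer heavy atoms and carries a hydrogen-bond donor that dimethylamino lacks, gives a 2.2-fold higher number from compound 2 to compound 3 (0.35 log units; beyond the scatter) and so moves the number upward. This position therefore responds to a change confined to the nitrogen substituents, and the direction seen here is away from the lower number held by compound 1. Exchanging the whole aryl group, with 3-aminophenyl in place of 4-fluorophenyl on a saturated ring carbon, gives a 16-fold higher number from compound 1 to compound 3 (1.19 log units; beyond the scatter) as a large step, and compound 3 now has the highest number of the three, with its steps to both others beyond the scatter.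

Going by these compounds, whether methylamino, with a single methyl on the nitrogen, would fall between compound 2 and compound 3 remains open. So does whether an acetamide or a hydroxyl group on the same aromatic carbon would follow the amino result or move the number the other way. No accompanying measurement bears on the origin of these steps.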